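Amide substituent exchange carried across two cores

This account rests on a few compounds, and the source may have more. Where it says the series, first, only, none or still open, it means among the compounds named here.

Compound 1 `O=C(c1cccc(C#Cc2ccccc2Nc2ncnc3ccc(Cl)nc23)c1)N1CCNCC1` carries a (piperazin-1-yl)carbonyl on the core it shares with compound 2 `CN(C)C(=O)c1cccc(C#Cc2ccccc2Nc2ncnc3ccc(Cl)nc23)c1`, which carries dimethylcarbamoyl instead. In an assay on isolated protein for inhibition of MAP kinase-interacting serine/threonine-protein kinase 2 (Homo sapiens), read by HTRF, in the presence of a further agent that is not named here (on this read-out lower numbers stand for stronger inhibition and higher numbers for weaker inhibition), compound 1 gives 5000 nM. In this assay compound 2 reaches only a limit, > 10000 nM, one of the values that sit at the limit of > 10000 nM in this assay, at which 1 of the 3 values shown sits. The change piperazin-1-yl in place of dimethylamino on a carbonyl carbon thus made an at least 2.0-fold lower number from compound 2 to compound 1 (0.30 log units; that floor lies within the scatter). Compound 3 `Cc1c(C(=O)N(C)C)oc2ccc(Nc3ncnc4ccc(Cl)nc34)cc12` carries dimethylcarbamoyl on a different core; the difference between the two cores is not broken down here. In this assay compound 3 gives 2200 nM, the lowest of the two numbers, with compound 1 the nearest and the gap between them beyond the scatter. Compound 4 `Cc1c(C(=O)N2CCNCC2)oc2ccc(Nc3ncnc4ccc(Cl)nc34)cc12` applies the same change to compound 3, (piperazin-1-yl in place of dimethylamino on a carbonyl carbon), at the same kind of place, a carbonyl carbon whose other neighbour is an aromatic carbon. The step is expected to be a 2.0-fold lower number from compound 3 to compound 4 (0.30 log units; within the scatter), set beside the earlier one, which rests on a floor only and so is read conservatively. Compound 4 is expected at 1100 nM, between 400 nM and 3500 nM.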

Compound 4, half-maximal inhibitory concentration: 1900 nM
For compound 4 the middle estimate is 1.7-fold (0.24 log units) below the measured one; measured number inside the range.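

In this assay, piperazin-1-yl in place of dimethylamino on a carbonyl carbon gives a 1.2-fold lower number from compound 3 to compound 4 (0.06 log units; within the scatter), so on this second core the exchange cannot be told apart from repeat measurement. Set beside the first core, the two steps do not separate: the same change on two cores in this assay, an at least 2.0-fold lower number (0.30 log units; that floor lies within the scatter) from compound 2 to compound 1 and a 1.2-fold lower number (0.06 log units; within the scatter) from compound 3 to compound 4; the limit leaves it open whether they differ. Compound 2 is recorded only as a limit, > 10000 nM, so the first step has a floor and no size, and the two cores show neither that the change carries over unaltered nor that it depends on the core.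

The compounds shown leave open whether other amine partners on the same carbonyl carbon, such as morpholin-4-yl or 4-methylpiperazin-1-yl, would read apart from dimethylamino and piperazin-1-yl on either core. Also open, as far as these compounds go, is whether a carboxylic acid in place of these amides would give a number beyond the scatter from them.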